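Trimming Benzyloxy to Methoxy on the Aryl Ether

The source may hold more compounds than are shown below. What is called first, only, known or untested is meant among the compounds shown, and "the series" means these compounds.

Measured in an assay on HEK293 cells for binding affinity to Free fatty acid receptor 1 (Homo sapiens), read by scintillation counting and radioligand binding, with a stated time of 1 h; on this read-out higher numbers stand for weaker inhibition and lower numbers for stronger inhibition:
- compound 1 `Cc1ccccc1Oc1ccc(N2C[C@@H](C(F)(F)F)C[C@H]2CC(=O)O)cc1` gives 35 nM
- compound 2 `Cc1cc(OCc2ccccc2)ccc1Oc1ccc(N2C[C@@H](C(F)(F)F)C[C@H]2CC(=O)O)cc1` gives 10 nM

Compound 2 holds the lowest of the two numbers; its nearest neighbour is compound 1, and the difference between them is a 3.5-fold lower number from compound 1 to compound 2 (0.54 log units; beyond the scatter), the change being benzyloxy in place of hydrogen on an aromatic carbon. The next compound, compound 3 `COc1ccc(Oc2ccc(N3C[C@@H](C(F)(F)F)C[C@H]3CC(=O)O)cc2)c(C)c1`, carries hydrogen in place of phenyl on a saturated chain carbon bound to an oxygen on an aromatic ring, so that the benzyloxy of compound 2 becomes a methoxy. Within the data shown here, the only measured step bearing on this is the one from compound 1 to compound 2, which was a 3.5-fold lower number from compound 1 to compound 2 (0.54 log units; beyond the scatter). Compound 3 undoes part of that addition, leaving a methoxy that stands between the bare hydrogen of compound 1 and the benzyloxy of compound 2. The number for compound 3 is therefore expected to move back toward that of compound 1, though not all the way. Compound 3 is expected to show a 2.0-fold higher number from compound 2 to compound 3 (0.30 log units; within the scatter). The estimate for compound 3 in this assay is 20 nM, with a range from 8 nM to 50 nM.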

Compound 3, inhibition constant: 39 nM
The estimate for compound 3 lay 2.0-fold (0.29 log units) below the measured number, and the stated range covers the measured number.
By their numbers in this assay, from the lowest: compound 2; then compounds 1 and 3 (each within the scatter of the next).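

In this assay cutting the benzyloxy back to methoxy gives a 3.9-fold higher number from compound 2 to compound 3 (0.59 log units; beyond the scatter) and this step lies beyond the scatter, so the gain that came with the benzyloxy is lost once the phenyl leaves. Methoxy in place of hydrogen on the aromatic carbon gives a 1.1-fold higher number from compound 1 to compound 3 (0.05 log units; within the scatter) and this step lies within the scatter, so methoxy and hydrogen cannot be told apart at this position, and of the three groups shown only benzyloxy stands apart from the other two. No evidence is at hand to say why the phenyl counts for so much here.

The compounds shown leave open whether the phenyl itself is what matters or whether another group on the same oxygen, such as a cyclohexylmethoxy or a pyridylmethoxy, would hold the gain. They also leave open how the length of the link behaves, since an ethoxy or a phenethyloxy would show whether the number changes gradually with the chain or only when a ring is present.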